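Methoxy for chloro in a weak antiproliferative series

A few compounds are considered here, and "the series" means these few. Any claim that something is new, unique, unknown or untested is made for them only; others in the source may bear on it.

Measured in a functional assay on A-375 cells (Homo sapiens) for antiproliferative activity, read by MTT assay, with a stated time of 72 h; on this read-out lower numbers stand for stronger inhibition and higher numbers for weaker inhibition:
compound 1 `COc1ncc(-c2ccc3c(c2)N(c2ccc(C)cc2)C(=O)CO3)cc1NS(=O)(=O)c1ccc(F)cc1`: 12900 nM
compound 2 `COc1ncc(-c2ccc3c(c2)N(c2ccc(F)cc2)C(=O)CO3)cc1NS(=O)(=O)c1ccc(F)cc1`: > 40000 nM
compound 3 `CC(C)N1C(=O)COc2ccc(-c3cnc(Cl)c(NS(=O)(=O)c4ccc(F)cc4)c3)cc21`: 25500 nM

The entry for compound 2, > 40000 nM, is a limit of this assay and not a number. Compound 3, at 25500 nM, lies within the usual scatter of compound 1, at 12900 nM.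

Compound 4 `COc1ncc(-c2ccc3c(c2)N(C(C)C)C(=O)CO3)cc1NS(=O)(=O)c1ccc(F)cc1` differs from compound 3 by methoxy in place of chloro on an aromatic carbon. Among the measured compounds shown here, no measured step makes this change. For the measured compounds named here, the only measured step, an at least 3.1-fold higher number from compound 1 to compound 2 (0.49 log units; beyond the scatter), is fluoro in place of methyl, a different change, and it bears on this one only loosely. Compound 1 carries the methoxy of compound 4 but differs from it elsewhere. The value of compound 1, 12900 nM, gives no sign of a large gain or loss. No step beyond the scatter is therefore expected in this assay. The expected change is an estimated 1.6-fold lower number from compound 3 to compound 4 (0.20 log units; within the scatter). For compound 4 the estimated value is 16000 nM, with an expected range of 5000 nM to 40000 nM.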

Compound 4, half-maximal inhibitory concentration: 9950 nM
Estimate against measurement, compound 4: 1.6-fold (0.21 log units) above, within the range that was stated.
By their numbers in this assay, from the lowest: compounds 4, 1 and 3 (each within the scatter of the next, the first and the last beyond it). At a limit, above all of these: compound 2.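

At this place, on an aromatic carbon next to the ring nitrogen, methoxy in place of chloro gives the first step measured for the position in this assay: a 2.6-fold lower number from compound 3 to compound 4 (0.41 log units; beyond the scatter) is modest, but it shows that the group here has a measurable bearing on the read-out. With methoxy held, the group on the amide-type nitrogen in a ring counts differently according to what isopropyl replaces, since a 1.3-fold lower number from compound 1 to compound 4 (0.11 log units; within the scatter) for 4-methylphenyl stands against an at least 4.0-fold lower number from compound 2 to compound 4 (0.60 log units; beyond the scatter) for 4-fluorophenyl. That second step has only one measured end, as compound 2 gives a limit of the assay and not a number: (the limit of > 40000 nM in this assay, at which 1 of the 4 values shown sits).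

Going by these compounds, whether methoxy in place of chloro gives a similar step with 4-methylphenyl on that nitrogen remains open. So does what an amine, a nitrile or a longer alkoxy chain would give at this place.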